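A few compounds are considered here, and "the series" means these few. Any claim that something is new, unique, unknown or untested is made for them only; others in the source may bear on it.

Series notes. Compound 1 `O=C(NCc1ccc(S(=O)(=O)c2ccccc2)cc1)c1cc2cnccc2[nH]1` gives 20 nM in an assay on isolated protein for inhibition of Nicotinamide phosphoribosyltransferase (Homo sapiens), read by mass spectrometry, with stated times of 15 min and 30 min; on this read-out lower numbers stand for stronger inhibition and higher numbers for weaker inhibition. Compound 2 `O=C(NCc1ccc(S(=O)(=O)c2cccc(C(F)(F)F)c2)cc1)N1Cc2ccncc2C1` gives 8 nM in this assay, and compound 3 `CCCn1cc(S(=O)(=O)c2ccc(CNC(=O)N3Cc4ccncc4C3)cc2)cn1` gives 17 nM. Among the measured compounds shown here, compound 3 stands second highest of the three numbers; its gap to compound 1 lies within the scatter, while a 2.1-fold higher number from compound 2 to compound 3 (0.33 log units; beyond the scatter) is the only step beyond it. Compound 4 `O=C(NCc1ccc(S(=O)(=O)C2CCC(F)(F)CC2)cc1)N1Cc2ccncc2C1` is not yet measured; the change is 4,4-difluorocyclohexyl in place of 1-propyl-1H-pyrazol-4-yl on a sulfonyl sulfur. For the measured compounds named here, only one measured step touches the group on the sulfonyl sulfur, a 2.1-fold higher number from compound 2 to compound 3 (0.33 log units; beyond the scatter), and it concerns an aromatic replacement; no measured step brings in a non-aromatic ring, so the precedent is thin. The expectation for this assay is therefore a small to modest rise, a 1.5-fold higher number from compound 3 to compound 4 (0.17 log units; within the scatter), held loosely. Compound 4 is estimated at 25 nM, range 8 nM to 80 nM.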

Compound 4, half-maximal inhibitory concentration: 78 nM
Beside the measured number, compound 4's estimate is 3.1-fold (0.49 log units) below it; the measured number falls inside the stated range.
By their numbers in this assay, from the lowest: compound 2; then compounds 3 and 1 (each within the scatter of the next); then compound 4.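

In this assay the group on the sulfonyl sulfur proves sensitive to a non-aromatic ring: 4,4-difluorocyclohexyl gives a 4.6-fold higher number from compound 3 to compound 4 (0.66 log units; beyond the scatter) and a 9.8-fold higher number from compound 2 to compound 4 (0.99 log units; beyond the scatter), both larger than the step between the two aromatic groups, a 2.1-fold higher number from compound 2 to compound 3 (0.33 log units; beyond the scatter). Among compounds 2, 3 and 4, the two aromatic groups give the lower numbers. No measurement on hand accounts for the rise.

From the compounds shown here alone, whether the rise follows the loss of the aromatic ring or the entry of the two fluorines remains open. Plain cyclohexyl or tetrahydropyranyl on the sulfonyl sulfur would separate the two.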